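The compounds below may be only part of what the source reports. "The series", "measured", "known", "first", "only" and "open" are said of these compounds alone.

In a functional assay on OVCAR-8 cells (Homo sapiens) for inhibition, read by colorimetric assay and sulforhodamine B assay, with a stated time of 48 h (on this read-out lower numbers stand for stronger inhibition of growth and higher numbers for weaker inhibition of growth), compound 2 `CCCCCCCCCCCC[C@@H](O)[C@H]1CC[C@H]([C@H](O)CCCCCCCCCCNC(=O)c2cncs2)O1` stands highest of the two measured compounds at 100000 nM while compound 1 `CCCCCCCCCCCC[C@@H](O)[C@H]1CC[C@H]([C@H](O)CCCCCCCCCCNC(=O)c2cccs2)O1` gives 3020 nM as the other number. Compound 3 `CCCCCCCCCCCC[C@@H](O)[C@H]1CC[C@H]([C@H](O)CCCCCCCCCCNC(=O)c2ccnn2C)O1` differs from compound 2 by 1-methyl-1H-pyrazol-5-yl in place of 1,3-thiazol-5-yl on a carbonyl carbon with 1-methyl-1H-pyrazol-5-yl in place of 1,3-thiazol-5-yl on a carbonyl carbon. For the measured compounds named here, the one measured step at this place is a 33-fold higher number from compound 1 to compound 2 (1.52 log units; beyond the scatter) and it is large, so a sizeable move is expected again, most likely toward a lower number since compound 2 holds the higher of the two. The expected change is a 5.6-fold lower number from compound 2 to compound 3 (0.74 log units; beyond the scatter) in this estimate. Compound 3 is therefore estimated at 18000 nM with an expected range from 4000 nM to 70000 nM around it.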

Compound 3, concentration for 50% growth inhibition: 30900 nM
Beside the measured number, compound 3's estimate is 1.7-fold (0.23 log units) below it; measured number inside the range.
By their numbers in this assay, from the lowest: compound 1; then compound 3; then compound 2.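

Entering 1-methyl-1H-pyrazol-5-yl on the carbonyl carbon gives a 3.2-fold lower number from compound 2 to compound 3 (0.51 log units; beyond the scatter) and still leaves a 10-fold higher number from compound 1 to compound 3 (1.01 log units; beyond the scatter) in this series. Among these three compounds, both rings with 2 hetero atoms therefore stand on the weaker side of thiophen-2-yl, yet the two rings are not equivalent to each other. No evidence here bears on the reason for these steps. As far as these compounds go, what remains open is how a phenyl ring or a pyridine ring would behave at this place, and how much the methyl on the pyrazole contributes.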